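Replacing the dichlorophenyl sulfonamide with a naphthyl sulfonamide

A few compounds are considered here, and "the series" means these few. Any claim that something is new, unique, unknown or untested is made for them only; others in the source may bear on it.

compound 1: `COc1cc2nc(N3CCN(S(=O)(=O)c4ccc(I)cc4)CC3)nc(N)c2cc1OC` — 15000 nM
compound 2: `COc1cc2nc(N3CCN(S(=O)(=O)c4ccc(S(C)(=O)=O)cc4)CC3)nc(N)c2cc1OC` — 17000 nM
compound 3: `COc1cc2nc(N3CCN(S(=O)(=O)c4cc(Cl)ccc4Cl)CC3)nc(N)c2cc1OC` — 60000 nM

In a functional assay on PC-3 cells (Homo sapiens) for inhibition (on this read-out lower numbers stand for stronger inhibition and higher numbers for weaker inhibition), compound 3 gives the highest number of the three measured compounds, and both of its steps from the others, a 4.0-fold higher number from compound 1 to compound 3 (0.60 log units; beyond the scatter) and a 3.5-fold higher number from compound 2 to compound 3 (0.55 log units; beyond the scatter), lie beyond the scatter. Compound 4, `COc1cc2nc(N3CCN(S(=O)(=O)c4cccc5ccccc45)CC3)nc(N)c2cc1OC`, differs from compound 3 by naphthalen-1-yl in place of 2,5-dichlorophenyl on a sulfonyl sulfur. For the measured compounds named here, no measured step involves a naphthyl group, so the only guidance is that the two exchanges of the aryl group on the sulfonyl sulfur each produced modest shifts, and that leaving the 2,5-dichlorophenyl group may reverse some of that. Compound 4 is therefore expected to move by about a 2.4-fold lower number from compound 3 to compound 4 (0.38 log units; beyond the scatter), estimated at 25000 nM in this assay, with a range from 8000 nM to 80000 nM.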

Compound 4, half-maximal inhibitory concentration: 14000 nM
The estimate for compound 4 lay 1.8-fold (0.25 log units) above the measured number, within the range that was stated.
By their numbers in this assay, from the lowest: compounds 4, 1 and 2 (each within the scatter of the next); then compound 3.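

In this assay the naphthalen-1-yl group on the sulfonyl sulfur gives a clear gain over 2,5-dichlorophenyl (a 4.3-fold lower number from compound 3 to compound 4 (0.63 log units; beyond the scatter)). It cannot be told apart from 4-(methylsulfonyl)phenyl (a 1.2-fold lower number from compound 2 to compound 4 (0.08 log units; within the scatter)) or from 4-iodophenyl (a 1.1-fold lower number from compound 1 to compound 4 (0.03 log units; within the scatter)), so among these four compounds, a second aromatic ring neither helps nor hurts relative to those two groups, and only 2,5-dichlorophenyl in compound 3 stands apart. No evidence at hand explains that difference. Still open, as far as these compounds go, is how an amine or a carboxylic acid on the aryl ring, or a cyclohexyl group in its place, would read here.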